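A few compounds are considered here, and "the series" means these few. Any claim that something is new, unique, unknown or untested is made for them only; others in the source may bear on it.

In an ADME assay on MT4 cells (Homo sapiens) for cytotoxicity, read by MTT assay, with a stated time of 96 h (a higher number here means that more compound is tolerated, a lower number that less compound is tolerated), compound 1 `COc1ccc(-c2nc3cc(C(C)=O)ccc3[nH]2)c(OC)c1` gives 50000 nM. Compound 2 `COc1ccc(-c2nc3cc(C(C)=O)ccc3[nH]2)c(OC)c1OC` reads > 100000 nM, which is a limit of the assay. Compound 3 `COc1ccc(-c2nc3cc(C(C)O)ccc3[nH]2)c(OC)c1` reads >= 100000 nM, again a limit and not a number, so its standing rests on no exact value. Compound 4 `COc1ccc(-c2nc3cc(C(C)O)ccc3[nH]2)c(OC)c1OC` differs from it by one change: methoxy in place of hydrogen on an aromatic carbon. The same exchange gave an at least 2.0-fold higher number from compound 1 to compound 2 (0.30 log units; that floor lies within the scatter). The other measured step, 1-hydroxyethyl in place of acetyl on an aromatic carbon, gave an at least 2.0-fold higher number from compound 1 to compound 3 (0.30 log units; that floor lies within the scatter). Both are only floors, so no step beyond the scatter is expected in this assay. The expected outcome is a number no higher from compound 3 to compound 4 (the limit leaves the size open). Compound 4 is estimated at 100000 nM, with an expected range from 50000 nM to 150000 nM.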

Compound 4, half-maximal cytotoxic concentration: 79000 nM
For compound 4 the middle estimate is 1.3-fold (0.10 log units) above the measured one, within the range that was stated.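

In this assay, methoxy in place of hydrogen on the core of compound 3 gives an at least 1.2-fold lower number from compound 3 to compound 4 (0.10 log units; that floor lies within the scatter), and 1-hydroxyethyl in place of acetyl on the core of compound 2 gives an at least 1.2-fold lower number from compound 2 to compound 4 (0.10 log units; that floor lies within the scatter), so neither exchange now shows a step beyond the scatter on its second core. For the methoxy, ortho to two methoxy groups, the two cores compare as follows: the same change on two cores in this assay, an at least 2.0-fold higher number (0.30 log units; that floor lies within the scatter) from compound 1 to compound 2 and an at least 1.2-fold lower number (0.10 log units; that floor lies within the scatter) from compound 3 to compound 4; the limit leaves it open whether they differ. For the 1-hydroxyethyl exchange, they compare as follows: the same change on two cores in this assay, an at least 2.0-fold higher number (0.30 log units; that floor lies within the scatter) from compound 1 to compound 3 and an at least 1.2-fold lower number (0.10 log units; that floor lies within the scatter) from compound 2 to compound 4; the limit leaves it open whether they differ. The compounds shown leave open whether an amine in place of the 1-hydroxyethyl, or a longer chain in place of this methoxy, would move the number beyond the scatter.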